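Methoxy on the core of compound 1: rat clearance

The compounds below may be only part of what the source reports. "The series", "measured", "known", "first", "only" and "open" are said of these compounds alone.

Measured in an ADME assay on the whole organism (Rattus norvegicus) for metabolic stability, at a dose of 1 mg/kg by the intravenous route; on this read-out lower numbers stand for slow clearance and higher numbers for fast clearance:
- compound 1 `Cc1ccc([C@H](C)NC(=O)Cn2nnc3ccccc3c2=O)cc1`: 62 mL/min/kg
- compound 2 `COc1cccc2nnn(CC(=O)N[C@@H](C)c3ccc(C)cc3)c(=O)c12`: 17 mL/min/kg

Compound 1 holds the highest of the two numbers in this assay. Compound 3 `COc1ccc2nnn(CC(=O)N[C@@H](C)c3ccc(C)cc3)c(=O)c2c1` carries methoxy in place of hydrogen on an aromatic carbon. Among the compounds with values here, one measured step bears on this, the same exchange in compound 2: a 3.6-fold lower number from compound 1 to compound 2 (0.56 log units; beyond the scatter), modest and beyond the scatter. Within the data shown here, no measurement yet shows methoxy on the carbon it occupies in compound 3, so a lower number is expected, but by a smaller step. The expected change is a 2.1-fold lower number from compound 1 to compound 3 (0.32 log units; beyond the scatter). The estimate for compound 3 is 30 mL/min/kg, with an expected range of 15 mL/min/kg to 60 mL/min/kg.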

Compound 3, clearance: 39 mL/min/kg
Estimate against measurement, compound 3: 1.3-fold (0.11 log units) below, and the stated range covers the measured number.
By their numbers in this assay, from the lowest: compound 2; then compounds 3 and 1 (each within the scatter of the next).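

In this assay methoxy on the carbon meta to a fused ring and para to a fused ring gives a 1.6-fold lower number from compound 1 to compound 3 (0.20 log units; within the scatter) and so does not separate compound 3 from compound 1. The same group on the carbon it occupies in compound 2 gave a 3.6-fold lower number from compound 1 to compound 2 (0.56 log units; beyond the scatter) and that step alone lies beyond the scatter, so the outcome of this exchange depends on the carbon carrying the methoxy. Nothing measured here accounts for that difference.

Still open, from the compounds shown here alone, is how the remaining aromatic carbons of the shared core respond to methoxy. Also open, going by these compounds, is whether ethoxy, fluorine or an amine on either carbon would follow methoxy.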